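The source may report more compounds than this note shows. Statements on the series, on what has been measured and on what is new or still open speak of the compounds shown alone.

Compound 1 `O=C1Nc2ccccc2/C1=N/NC(=S)Nc1cccnc1`: in a functional assay on KB 3-1 cells (Homo sapiens) for cytotoxicity, read by MTT assay, with a stated time of 72 h (a higher number here means a weaker inhibitor, a lower number a stronger inhibitor), compound 1 reaches only the assay limit of > 50000 nM.
Compound 2 `CNC(=S)N/N=C1\C(=O)Nc2ccccc21`: compound 2 gives 35300 nM.
Compound 3 `O=C1Nc2ccccc2/C1=N/NC(=S)Nc1ccc(Cl)cc1`: compound 3 gives 13400 nM.

Compound 3 gives the lowest of the two numbers, the nearest being compound 2 with a 2.6-fold lower number from compound 2 to compound 3 (0.42 log units; beyond the scatter). Compound 4 `CC(C)(C)c1ccc(NC(=S)N/N=C2\C(=O)Nc3ccccc32)cc1` differs from compound 3 by tert-butyl in place of chloro on an aromatic carbon. The measured steps, an at least 1.4-fold lower number from compound 1 to compound 2 (0.15 log units; that floor lies within the scatter), an at least 3.7-fold lower number from compound 1 to compound 3 (0.57 log units; beyond the scatter) and a 2.6-fold lower number from compound 2 to compound 3 (0.42 log units; beyond the scatter), all exchange the group on the amide-type nitrogen; none alters a substituent on the aromatic ring, so none bears directly on this change. Going by the values given here, with no comparable step to draw on, compound 4 is expected to show a step of a 1.2-fold lower number from compound 3 to compound 4 (0.09 log units; within the scatter), one that would lie within the scatter. Compound 4 is therefore estimated at 11000 nM, with a range from 3500 nM to 35000 nM.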

Compound 4, half-maximal inhibitory concentration: 8130 nM
Estimate against measurement, compound 4: 1.4-fold (0.13 log units) above; the range from low to high includes it.
By their numbers in this assay, from the lowest: compounds 4 and 3 (each within the scatter of the next); then compound 2. At a limit, above all of these: compound 1.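

Swapping the group on an aromatic carbon, rather than on the amide-type nitrogen, gives in this assay a 1.6-fold lower number from compound 3 to compound 4 (0.22 log units; within the scatter). Compound 3 and compound 4 therefore cannot be told apart at this position, even though tert-butyl brings 4 heavy atoms where chloro brought 1. Nothing given here accounts for this result. As far as these compounds go, it remains open whether an amine, a carboxylic acid or a longer chain on this carbon would read the same, and whether a second substituent on the ring would change the number.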